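Sulfonyl amine swap in the ester-bearing sulfonamide series

A few compounds are considered here, and "the series" means these few. Any claim that something is new, unique, unknown or untested is made for them only; others in the source may bear on it.

Compound 2 `CCOC(=O)[C@@H]1CCCN(S(=O)(=O)c2ccc(S(=O)(=O)N3CCCCC3)cc2)C1` sits second highest of the three numbers in a functional assay on MIA PaCa-2 cells (Homo sapiens) for inhibition, read by MTT assay, with a stated time of 7 days (a higher number here means a weaker inhibitor, a lower number a stronger inhibitor), where compound 2 gives 2900 nM. Compound 1 `CCOC(=O)[C@@H]1CCCN(S(=N)(=O)c2ccc(S(=O)(=O)N(CC)CC)cc2)C1` gives 12100 nM, a gap above compound 2 that is beyond the scatter. Compound 3 `CCN(CC)S(=O)(=O)c1ccc(S(=O)(=O)N2CCC[C@@H](C(=O)N3CCC(c4nc(C(C)C)no4)CC3)C2)cc1` gives 40 nM, far below the other two and also beyond the scatter. Compound 4 `CCOC(=O)[C@@H]1CCCN(S(=O)(=O)c2ccc(S(=O)(=O)N3CCOCC3)cc2)C1` has not been measured; it differs from compound 2 in one place: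

morpholin-4-yl in place of piperidin-1-yl on a sulfonyl sulfur

Within the data shown here, no measured pair isolates this change, so no step between measured compounds guides it. The expected step of a 1.4-fold higher number from compound 2 to compound 4 (0.14 log units; within the scatter) is small, within or close to the scatter, with a slight lean toward a higher number. Compound 4 is expected to give 4000 nM, with a range from 1500 nM to 12000 nM.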

Compound 4, half-maximal inhibitory concentration: 23500 nM
Compound 4: the middle estimate sits 5.9-fold (0.77 log units) below what was measured, and the stated range ends below it.
By their numbers in this assay, from the lowest: compound 3; then compound 2; then compounds 1 and 4 (each within the scatter of the next).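

In this assay, this sulfonyl position proves sensitive to the choice of ring: morpholin-4-yl in place of piperidin-1-yl gives an 8.1-fold higher number from compound 2 to compound 4 (0.91 log units; beyond the scatter). Both rings are six-membered with the same heavy-atom count, and the change exchanges a ring carbon for an oxygen, with one hydrogen-bond acceptor entering. No supporting measurement accounts for the size of this step.

Still open, as far as these compounds go, is whether thiomorpholin-4-yl or 4-methylpiperazin-1-yl on the sulfonyl sulfur would track with compound 2 or compound 4. The same question stands for an acyclic amine such as dimethylamino.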